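The compounds below may be only part of what the source reports. "The series", "measured", "known", "first", "only" and "open" are said of these compounds alone.

Two members of the series are measured in an assay on isolated protein for inhibition of glutathione S-transferase P (Homo sapiens), with a stated time of 10 min; a lower number here means a stronger inhibitor, a higher number a weaker inhibitor. Compound 1 `O=C(CCC(=O)OCCCCCCSc1ccc([N+](=O)[O-])c2nonc12)Nc1ccccc1F` gives 9890 nM. For the measured compounds named here, compound 2 `O=C(CCC(=O)OCCCCCCSc1ccc([N+](=O)[O-])c2nonc12)Nc1cccc(Cl)c1` gives 28800 nM, the higher of the two numbers, the only other being compound 1. Going by the values given here, the one measured step, a 2.9-fold higher number from compound 1 to compound 2 (0.46 log units; beyond the scatter), comes from exchanging one aryl group for another on the amide-type nitrogen. Compound 3 `O=C(CCC(=O)OCCCCCCSc1ccc([N+](=O)[O-])c2nonc12)Nc1ccc(C(F)(F)F)cc1` differs from compound 2 by 4-(trifluoromethyl)phenyl in place of 3-chlorophenyl on an amide-type nitrogen. Among the compounds with values here, no measured pair shows this particular exchange; a 2.9-fold higher number from compound 1 to compound 2 (0.46 log units; beyond the scatter) is the only guide to how far an aryl exchange at this position moves this assay, and it was modest. A change beyond the scatter in either direction cannot be ruled out, but none is clearly indicated. Compound 3 is therefore expected to give about 25000 nM, with a range from 8000 nM to 80000 nM. The implied step, a 1.2-fold lower number from compound 2 to compound 3 (0.06 log units; within the scatter), is expected to lie within the scatter.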

Compound 3, half-maximal inhibitory concentration: 5050 nM
The estimate for compound 3 lay 5.0-fold (0.69 log units) above the measured number; measured number outside the range, below it.
By their numbers in this assay, from the lowest: compounds 3 and 1 (each within the scatter of the next); then compound 2.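

In this assay, exchanging 3-chlorophenyl for 4-(trifluoromethyl)phenyl on the amide-type nitrogen gives a step in the lowering direction (a 5.7-fold lower number from compound 2 to compound 3 (0.76 log units; beyond the scatter)), so an aryl exchange at this position can move the number down as well as up. The step against 2-fluorophenyl (a 2.0-fold lower number from compound 1 to compound 3 (0.29 log units; within the scatter)) leaves compound 3 and compound 1 indistinguishable, and compound 2 alone stands apart among the three. The group with 10 heavy atoms therefore gives no higher number than either group it is compared with, and all steps beyond the scatter at this position remain modest.

No measured evidence accounts for these differences. From the compounds shown here alone, the exchange from compound 2 to compound 3 alters both the substituent and its ring position, so the two contributions cannot be separated, and the effect of an amine or a carboxylic acid on the aryl ring remains open.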